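Swapping the ether at the aromatic carbon for a thioether

The compounds below may be only part of what the source reports. "The series", "measured", "known", "first", "only" and "open" are said of these compounds alone.

Measured so far:
Compound 1 `CCC1CCN(c2cc(C(F)(F)F)ccc2CNC(=O)C(C)c2ccc(NS(C)(=O)=O)c(F)c2)CC1`: 0.7 nM
Compound 2 `CC(C(=O)NCc1ccc(C(F)(F)F)cc1N1CCC(C(F)(F)F)CC1)c1ccc(NS(C)(=O)=O)c(F)c1`: 0.4 nM
Compound 3 `CC(C(=O)NCc1ccc(C(F)(F)F)cc1OC1CCCC1)c1ccc(NS(C)(=O)=O)c(F)c1`: 0.6 nM

All three compounds were tested in an assay on CHO cells for antagonist activity at transient receptor potential cation channel subfamily V member 1 (Homo sapiens), read by FLIPR; on this read-out higher numbers stand for weaker inhibition and lower numbers for stronger inhibition. Compound 3 differs from compound 1 by a 1.2-fold lower number from compound 1 to compound 3 (0.07 log units; within the scatter) and from compound 2 by a 1.5-fold higher number from compound 2 to compound 3 (0.18 log units; within the scatter), so the three numbers cannot be told apart on this read-out.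

Compound 4 `CC(C)CCSc1cc(C(F)(F)F)ccc1CNC(=O)C(C)c1ccc(NS(C)(=O)=O)c(F)c1` has not been measured in this assay. It differs from compound 3 in one place: isopentylsulfanyl in place of cyclopentyloxy on an aromatic carbon. The two measured steps that touch this same aromatic carbon, a 1.2-fold lower number from compound 1 to compound 3 (0.07 log units; within the scatter) and a 1.5-fold higher number from compound 2 to compound 3 (0.18 log units; within the scatter), exchange groups of quite different make-up there and both stay within the scatter. Among the measured compounds shown here, nothing among the measured compounds shows a swap of oxygen for sulfur or of a ring for a chain at this position, so the expectation rests on the tolerance those two steps suggest. No step beyond the scatter is expected in this assay, in either direction.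

Compound 4 is therefore estimated at 0.8 nM, with a range of 0.3 nM to 2.5 nM, which amounts to an expected step of a 1.3-fold higher number from compound 3 to compound 4 (0.12 log units; within the scatter).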

Compound 4, inhibition constant: 1.4 nM
Compound 4: middle estimate off by 1.8-fold (0.24 log units), on the low side, within the range that was stated.
By their numbers in this assay, from the lowest: compounds 2, 3, 1 and 4 (each within the scatter of the next, the first and the last beyond it).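

Among the compounds shown here, at this aromatic carbon, isopentylsulfanyl is the first group to give a step beyond the scatter in this assay, with a 2.3-fold higher number from compound 3 to compound 4 (0.37 log units; beyond the scatter) and a 3.5-fold higher number from compound 2 to compound 4 (0.54 log units; beyond the scatter), both modest, while a 2.0-fold higher number from compound 1 to compound 4 (0.30 log units; within the scatter) stays within the scatter. The position therefore does not take every group equally, although the cyclopentyloxy and the two substituted piperidin-1-yl groups could not be told apart there, and the change seen remains small. Nothing measured here accounts for this shift.

The step from compound 3 to compound 4 exchanges oxygen for sulfur and a ring for a chain at once, so the compounds shown cannot say which exchange matters. Isopentyloxy or cyclopentylsulfanyl at this carbon would separate the two, and neither is among the compounds shown.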